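The source may report more compounds than this note shows. Statements on the series, on what has been measured and on what is new or still open speak of the compounds shown alone.

Compound 1, with the structure `O=C(CCCCCONC(=O)Nc1cnc2ccccc2c1)NO`, was tested in an assay on cells for inhibition of protein deacetylase HDAC6 (Homo sapiens), read by fluorescence, with a stated time of 90 min; a higher number here means a weaker inhibitor, a lower number a stronger inhibitor; there compound 1 gives 51.7 nM. Compound 2, with the structure `COc1cc(NC(=O)NOCCCCCC(=O)NO)c2ncccc2c1`, carries a methoxy group on the shared core, and in this assay compound 2 gives 6.1 nM. Among the two numbers measured, compound 2 stands lowest, and its gap to compound 1 lies beyond the scatter of repeated measurements, so compound 2 is the stronger inhibitor of the pair.

Compound 3, with the structure `COc1cc(NC(=O)NOCCCCCC(=O)NO)c2nccc(C)c2c1`, differs from compound 2 in one place: methyl in place of hydrogen on an aromatic carbon. Going by the values given here, no step between measured compounds involves a change of this kind, so there is nothing measured to lean on. The change is a single methyl group on the shared core, and the expectation is a step of no more than the usual scatter, in either direction, with the number of compound 3 staying close to that of compound 2. Compound 3 is therefore estimated at 7 nM in this assay, with a range from 3 nM to 18 nM, which amounts to an expected step of a 1.1-fold higher number from compound 2 to compound 3 (0.06 log units; within the scatter).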

Compound 3, half-maximal inhibitory concentration: 24.8 nM
Beside the measured number, compound 3's estimate is 3.5-fold (0.55 log units) below it; the measured number lies above the stated range.
By their numbers in this assay, from the lowest: compound 2; then compound 3; then compound 1.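

In this assay, the aromatic carbon opposite the ring nitrogen proves sensitive to change: putting methyl in place of hydrogen there gives a 4.1-fold higher number from compound 2 to compound 3 (0.61 log units; beyond the scatter). This single step shows that the position does not accept every addition freely, since adding one carbon atom, with no ring, no net charge and no hydrogen-bond donors or acceptors, moves the number beyond the scatter and weakens the inhibitor. Nothing available explains why this small addition raises the number.

Going by these compounds alone, with only one change at this carbon, it remains open whether the rise is particular to methyl or whether an ethyl group, a chlorine atom or an amine in the same place would give a larger step, a smaller step or none at all. As far as these compounds go, it is also open whether the same methyl would give a step of similar size on a core without the methoxy group, such as the core of compound 1.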